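A few compounds are considered here, and "the series" means these few. Any claim that something is new, unique, unknown or untested is made for them only; others in the source may bear on it.

In a functional assay on MIA PaCa-2 cells (Homo sapiens) for cytotoxicity, read by fluorescence, with a stated time of 48 h (a lower number here means that less compound is needed, a higher number that more compound is needed for the effect), compound 1 (`CC(C)=CCC/C(C)=C/CC/C(C)=C/CSC[C@H](NC(=O)CCCCCN1CCCC1)C(=O)NC1CCCCCCC1`) gives 1900 nM. Compound 2 (`CC(C)=CCC/C(C)=C/CC/C(C)=C/CSC[C@H](NC(=O)CCCCCN1CCCC1)C(=O)NC1CC1`) gives > 20000 nM, which is a limit of the assay and not a number. Compound 2 therefore stands at the top of the range shown: the limit of > 20000 nM in this assay, at which 1 of the 2 values shown sits.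

Compound 3 (`CC(C)=CCC/C(C)=C/CC/C(C)=C/CSC[C@H](NC(=O)CCCCCN1CCCC1)C(=O)N1CCCC1`) carries pyrrolidin-1-yl in place of cyclopropylamino on a carbonyl carbon. The amide hydrogen of compound 2 is thus lost. For the measured compounds named here, only one measured step bears on this change, and only indirectly: an at least 10-fold higher number from compound 1 to compound 2 (1.02 log units; beyond the scatter). That large step also altered the group on the amide-type nitrogen, but it went from cyclooctyl to cyclopropyl, and compound 3 does not bring the cyclooctyl group back. Going by the values given here, no measured step tests the loss of the amide hydrogen.

In this assay, no step beyond the scatter is therefore expected, and the result may again be only a limit. The estimated step is an at least 1.1-fold lower number from compound 2 to compound 3 (0.04 log units; that floor lies within the scatter). For compound 3 the expected value is 18000 nM, with an estimated range from 7000 nM to 40000 nM.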

Compound 3, half-maximal effective concentration in the MIA PaCa-2 assay: 10800 nM
Compound 3: middle estimate off by 1.7-fold (0.22 log units), on the high side; measured number inside the range.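

With compound 3, the ring group on the carbonyl carbon can be compared with cyclooctylamino in the MIA PaCa-2 assay, where compound 1 gives 1900 nM and compound 3 gives 10800 nM, and pyrrolidin-1-yl in place of cyclooctylamino gives a 5.7-fold higher number from compound 1 to compound 3 (0.75 log units; beyond the scatter), so compound 3 remains on the weaker side of compound 1. Compound 2 has only a limit, not a number, in this comparison: the limit of > 20000 nM in the MIA PaCa-2 assay, at which 1 of the 3 values shown sits. Against that limit, in the MIA PaCa-2 assay the change from cyclopropylamino to pyrrolidin-1-yl gives an at least 1.8-fold lower number from compound 2 to compound 3 (0.26 log units; that floor lies within the scatter), so the loss of the amide hydrogen still leaves a measured value in this assay, although the step cannot be called a real gain. In a physicochemical assay for lipophilicity (a higher number here means a more lipophilic compound, a lower number a more polar compound), compound 2 gives 3.15 and compound 3 gives 3.31, and the same change gives a number 0.16 log units higher from compound 2 to compound 3 (within the scatter).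

The compounds shown do not separate ring size from the loss of the amide hydrogen, as the step to compound 3 from compound 1 changes both at once. An azocan-1-yl or piperidin-1-yl group on the same carbonyl carbon would show how far a larger ring without the amide hydrogen follows cyclooctylamino or stays with pyrrolidin-1-yl.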